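The source may hold more compounds than are shown below. What is called first, only, known or untested is meant among the compounds shown, and "the series" means these compounds.

Of the compounds shown here, three have so far been measured in an assay on isolated protein for inhibition of protein deacetylase HDAC6 (Homo sapiens); on this read-out lower numbers stand for stronger inhibition and higher numbers for weaker inhibition. Compound 1 `COc1cc(C(=O)c2ccc3c(ccn3S(=O)(=O)c3ccc(/C=C/C(=O)NO)cc3)c2)cc(OC)c1OC` gives 972 nM, and compound 3 `COc1cccc(C(=O)c2ccc3c(ccn3S(=O)(=O)c3cccc(/C=C/C(=O)NO)c3)c2)c1` gives 1810 nM. Compound 2 `O=C(NO)c1ccc(Cn2ccc3cc(C(=O)c4ccc(F)cc4)ccc32)cc1` gives 9.25 nM, the lowest of the three numbers; compound 1 stands nearest to it and compound 3 furthest, and both gaps lie beyond the usual scatter, so compound 2 is the most potent compound among those measured.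

Compound 4 `O=C(NO)c1ccc(Cn2ccc3cc(C(=O)c4ccc(Cl)cc4)ccc32)cc1` has not yet been measured. It differs from compound 2 in a single place: chloro in place of fluoro on an aromatic carbon. Within the data shown here, no measured pair in this set shows the same exchange, so there is no measured step to lean on. Because compound 2 gives 9.25 nM and the exchange is a single atom for a single atom, the expectation is that compound 4 stays close to compound 2 in this assay, with no step beyond the scatter in either direction. Compound 4 is estimated at 10 nM, with a range from 4 nM to 25 nM. The estimate means a step of a 1.1-fold higher number from compound 2 to compound 4 (0.03 log units; within the scatter), expected to lie within the scatter.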

Compound 4, half-maximal inhibitory concentration: 6.73 nM
Beside the measured number, compound 4's estimate is 1.5-fold (0.17 log units) above it; low and high end bracket the measured number.
By their numbers in this assay, from the lowest: compounds 4 and 2 (each within the scatter of the next); then compounds 1 and 3 (each within the scatter of the next).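

In this assay, chloro in place of fluoro on an aromatic carbon, para to a large group, gives a 1.4-fold lower number from compound 2 to compound 4 (0.14 log units; within the scatter) and so stays within the scatter. Among these compounds, this is the only step in the set between compounds that differ in one place, and it shows that at this position the two halogens cannot be told apart on this read-out. Nothing measured here offers an explanation for this result.

The compounds shown leave open whether the position tolerates anything beyond these two halogens, such as bromo, a nitrile, an amine or a carboxylic acid. They also leave open whether the same exchange would give a step of similar size on the cores of compound 1 and compound 3, or against any other deacetylase.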